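Substitution on the ring nitrogen of compound 1

The source may hold more compounds than are shown below. What is called first, only, known or untested is meant among the compounds shown, and "the series" means these compounds.

Measured compounds:
compound 1 `O=C1c2c[n+]([O-])c3ccccc3c2C(=O)c2[nH]c3ccccc3c21` — 660 nM
compound 2 `CC1(C)OC[C@@H](Cn2cc(Cn3c4c(c5ccccc53)C(=O)c3c[n+]([O-])c5ccccc5c3C4=O)nn2)O1` — 450 nM
compound 3 `CC1(C)OC[C@H](Cn2cc(Cn3c4c(c5ccccc53)C(=O)c3c[n+]([O-])c5ccccc5c3C4=O)nn2)O1` — 180 nM

In a functional assay on A-375 cells (Homo sapiens) for cytotoxicity, read by MTT assay, with a stated time of 72 h (a higher number here means a weaker inhibitor, a lower number a stronger inhibitor), compound 1 gives 660 nM, the highest of the three numbers; the gap to compound 2 is within the scatter, the gap to compound 3 beyond it. Going by the values given here, the only step between two measured compounds that differ in one place is a 2.5-fold lower number from compound 2 to compound 3 (0.40 log units; beyond the scatter). Among the compounds with values here, because of the fact that compounds 2 and 3 differ only in the configuration as drawn that step says nothing about what a group placed on the aromatic nitrogen does; what the three values show together is only that both compounds carrying a group on that nitrogen give numbers no higher than compound 1.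

Compound 4 `CN(C)CCCCCn1c2c(c3ccccc31)C(=O)c1c[n+]([O-])c3ccccc3c1C2=O` carries 5-(dimethylamino)pentyl in place of hydrogen on an aromatic nitrogen. Within the data shown here, no measured step covers a chain of this kind on that nitrogen, so the expectation rests on compounds 2 and 3 lying at or below compound 1. For compound 4 a small to modest lowering is expected, a 2.1-fold lower number from compound 1 to compound 4 (0.31 log units; beyond the scatter), with wide uncertainty. Compound 4 is thus estimated at 320 nM, with a range from 100 nM to 1000 nM.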

Compound 4, half-maximal inhibitory concentration: 560 nM
For compound 4 the middle estimate is 1.8-fold (0.24 log units) below the measured one; low and high end bracket the measured number.
By their numbers in this assay, from the lowest: compound 3; then compounds 2, 4 and 1 (each within the scatter of the next).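

With this assay, 5-(dimethylamino)pentyl in place of hydrogen on an aromatic nitrogen gives a 1.2-fold lower number from compound 1 to compound 4 (0.07 log units; within the scatter). So the hydrogen on this nitrogen can be replaced by this open chain, with no ring and a terminal dimethylamino group, without a readable shift in the number, and the hydrogen itself is not required for a value in this range. This is the first step that reads a group on that nitrogen directly against hydrogen, as the only earlier step could not do so, because of this: the fact that compounds 2 and 3 differ only in the configuration as drawn

From the compounds shown here alone, whether the flat result holds for a shorter or longer chain remains open. So does the effect of replacing the terminal dimethylamino group with a primary amine, a morpholine or a carboxylic acid.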